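Swapping the pendant phenyl ring on a fused core

The compounds below may be only part of what the source reports. "The series", "measured", "known", "first", "only" and "open" are said of these compounds alone.

Measured in an assay for binding affinity to dual specificity mitogen-activated protein kinase kinase 4 (Homo sapiens), read by KINOMEscan, tested at 100 nM; on this read-out lower numbers stand for a stronger effect and higher numbers for a weaker effect at the one concentration tested:
- compound 1 `CCCS(=O)(=O)Nc1ccc(F)c(C(=O)c2n[nH]c3ncc(-c4ccc(OC)cc4)cc23)c1F`: 4.2%
- compound 2 `CCCS(=O)(=O)Nc1ccc(F)c(C(=O)c2n[nH]c3ncc(-c4ccc(N)cc4)cc23)c1F`: 0.1%
- compound 3 `CCCS(=O)(=O)Nc1ccc(F)c(C(=O)c2n[nH]c3ncc(-c4cccc(C(F)(F)F)c4)cc23)c1F`: 57%

On these numbers compound 1 stands second highest of three. Its nearest neighbour is compound 2, with a number 4.1 percentage points lower from compound 1 to compound 2 (within the scatter); its furthest is compound 3, with a number 52.8 percentage points higher from compound 1 to compound 3 (beyond the scatter). Compound 4 `CCCS(=O)(=O)Nc1ccc(F)c(C(=O)c2n[nH]c3ncc(-c4cccc([N+](=O)[O-])c4)cc23)c1F` is not yet measured. It differs from compound 1 only in the pendant phenyl ring: 3-nitrophenyl in place of 4-methoxyphenyl on an aromatic carbon. Within the data shown here, the step that bears most on this is the one to compound 3, where a 3-(trifluoromethyl)phenyl likewise replaced the 4-methoxyphenyl, giving a number 52.8 percentage points higher from compound 1 to compound 3 (beyond the scatter), and the related a number 56.9 percentage points higher from compound 2 to compound 3 (beyond the scatter) points the same way. Both show that leaving the para-substituted ring for a 3-substituted one went with a large rise. A rise of comparable size is therefore expected for compound 4, though a nitro group is not a trifluoromethyl group, so the range is wide. Compound 4 is expected to give about 40%, between 10% and 80%. For compound 4 the expected step is a number 35.8 percentage points higher from compound 1 to compound 4 (beyond the scatter).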

Compound 4, a percentage reported as activity, at one concentration (the size of the read-out at that concentration, not a potency): 15%
For compound 4 the middle estimate is 25 percentage points above the measured one; the measured number falls inside the stated range.
By their numbers in this assay, from the lowest: compounds 2 and 1 (each within the scatter of the next); then compound 4; then compound 3.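

Compound 4 shows that the large rise seen with compound 3 does not come with every replacement of the 4-substituted rings. On the same ring carbon, putting nitro in place of trifluoromethyl gives a number 42 percentage points lower from compound 3 to compound 4 (beyond the scatter) in this assay. The 3-nitrophenyl ring still costs something against the two 4-substituted rings, but only modestly, with a number 10.8 percentage points higher from compound 1 to compound 4 (beyond the scatter) and a number 14.9 percentage points higher from compound 2 to compound 4 (beyond the scatter), so the identity of the group, and not only the change of ring pattern, goes with the size of the effect.

Nothing measured here accounts for the gap between the nitro and trifluoromethyl compounds. Going by these compounds, it also remains open how this read-out would respond to a nitrile, a carboxylic acid or a longer alkyl chain on the pendant phenyl ring.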